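This account rests on a few compounds, and the source may have more. Where it says the series, first, only, none or still open, it means among the compounds named here.

In a functional assay on the whole organism with Mus musculus as the target (on this read-out higher numbers stand for an effect only at larger amounts of compound and lower numbers for an effect already at smaller amounts), compound 1 (`Cc1c(C)c2c(c(C)c1N)CC(C)(C)O2`) gives 7.8 mg/kg. Compound 2 (`Cc1c(C)c2c(c(C)c1NC=O)CC(C)(C)O2`) gives > 100 mg/kg, which is a limit of the assay and not a number. Compound 2 therefore stands on (the limit of > 100 mg/kg in this assay, at which 1 of the 2 values shown sits). Within the data shown here, the only measured step is an at least 12-fold higher number from compound 1 to compound 2 (1.10 log units; beyond the scatter), a large one, beyond the scatter, and its size is bounded by that limit. It placed formyl on the nitrogen on the aromatic ring. Compound 3 (`CC(=O)Nc1c(C)c(C)c2c(c1C)CC(C)(C)O2`) differs from compound 2 by methyl in place of hydrogen on a carbonyl carbon, or formylamino to acetamido. Among the measured compounds shown here, no measured step covers this exchange directly, but compound 3 keeps the carbonyl on that nitrogen, the feature introduced in an at least 12-fold higher number from compound 1 to compound 2 (1.10 log units; beyond the scatter). In this assay no change beyond the scatter is therefore expected, and a return towards compound 1 is not assumed. The expected step is a number no higher from compound 2 to compound 3 (the limit leaves the size open). For compound 3 the estimated value is 100 mg/kg, with an expected range from 30 mg/kg to 300 mg/kg.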

Compound 3, dose for 50% inhibition: > 100 mg/kg
Compound 3 ended at the assay's limit (the forecaster's own chance of this, stated with the estimate: 65%); the middle value lies on the limit itself.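

In this assay compound 3 gives > 100 mg/kg, which is a limit of the assay and not a number. Acetyl in place of hydrogen on the nitrogen on the aromatic ring gives an at least 12-fold higher number from compound 1 to compound 3 (1.10 log units; beyond the scatter), so the large step at this nitrogen is not confined to formyl and holds for both carbonyl groups shown. The step between the formylamino and acetamido compounds cannot be read, so methyl in place of hydrogen on the carbonyl carbon cannot be ranked: the limit of > 100 mg/kg in this assay, at which 2 of the 3 values shown sit.

Open, going by these compounds, is whether a methyl group or a longer alkyl chain on this nitrogen, with no carbonyl, would stay near compound 1 at 7.8 mg/kg. Also open, on these data alone, is whether a urea, a carbamate or a sulfonamide at the same nitrogen would behave like acetyl.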